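Amide aryl swap: compound 2 to compound 3

The source may hold more compounds than are shown below. What is called first, only, known or untested is meant among the compounds shown, and "the series" means these compounds.

Among the measured compounds shown here, compound 2 `Cc1cccc(NC(=O)c2ccc(/N=N\c3c[nH]c4ccccc34)cc2)c1C` stands at the top of the two numbers so far: in a functional assay on HCT-116 cells (Homo sapiens) for inhibition, read by MTT assay, with a stated time of 72 h (on this read-out higher numbers stand for weaker inhibition and lower numbers for stronger inhibition), compound 2 gives 272000 nM, whereas compound 1 `Cc1ccc(NC(=O)c2ccc(/N=N\c3c[nH]c4ccccc34)cc2)cc1` gives 25400 nM, and the step of an 11-fold higher number from compound 1 to compound 2 (1.03 log units; beyond the scatter) is the only one measured. Compound 3 `O=C(Nc1ccccc1[N+](=O)[O-])c1ccc(/N=N\c2c[nH]c3ccccc23)cc1` carries the change (2-nitrophenyl in place of 2,3-dimethylphenyl on an amide-type nitrogen). For the measured compounds named here, no measured step exchanges a dimethylphenyl for a nitrophenyl, so the step of an 11-fold higher number from compound 1 to compound 2 (1.03 log units; beyond the scatter) bears on it only as a sign that the substituent on this nitrogen can move this assay strongly. A change of uncertain direction is therefore expected for compound 3, a 3.9-fold lower number from compound 2 to compound 3 (0.59 log units; beyond the scatter), estimated at 70000 nM with a range of 15000 nM to 350000 nM.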

Compound 3, half-maximal inhibitory concentration: 208000 nM
Compound 3: middle estimate off by 3.0-fold (0.47 log units), on the low side; low and high end bracket the measured number.
By their numbers in this assay, from the lowest: compound 1; then compounds 3 and 2 (each within the scatter of the next).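

In this assay the step of a 1.3-fold lower number from compound 2 to compound 3 (0.12 log units; within the scatter) shows that 2-nitrophenyl and 2,3-dimethylphenyl on the amide-type nitrogen are not told apart, although the two groups differ in their atoms and hydrogen-bond acceptors. The step of an 8.2-fold higher number from compound 1 to compound 3 (0.91 log units; beyond the scatter) shows that compound 1 stands apart from a second replacement, not only from the 2,3-dimethylphenyl group. No supporting measurement bears on these numbers. On these data alone, whether the separation belongs to the 4-methylphenyl group of compound 1 remains open. As far as these compounds go, how an unsubstituted phenyl or an aminophenyl group on this nitrogen would read also remains open.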